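Cyclohexyl for Butyl on the Thiophene of Compound 1

A few compounds are considered here, and "the series" means these few. Any claim that something is new, unique, unknown or untested is made for them only; others in the source may bear on it.

Measured compounds:
compound 1, `CCCCc1csc(CN[C@@H]2C[C@H]3C[C@@H]([C@H]2C)C3(C)C)c1`, 12500 nM
compound 2, `Cc1ccsc1CN[C@@H]1C[C@H]2C[C@@H]([C@H]1C)C2(C)C`, 10000 nM
compound 3, `C[C@H]1[C@H](NCc2ccco2)C[C@H]2C[C@@H]1C2(C)C`, 50000 nM

In an ADME assay on MDCK cells (Canis lupus familiaris) for cytotoxicity, read by microscopy, with a stated time of 48 h (a lower number here means that less compound is tolerated, a higher number that more compound is tolerated), compound 1 stands second highest of the three numbers. Its nearest neighbour is compound 2, whose value lies within the scatter of that of compound 1, so the two cannot be told apart. Compound 3 gives the highest number of the set.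

Compound 4, `C[C@H]1[C@H](NCc2cc(C3CCCCC3)cs2)C[C@H]2C[C@@H]1C2(C)C`, differs from compound 1 in one place: cyclohexyl in place of butyl on an aromatic carbon.

Among the measured compounds shown here, only one step is recorded among the measured compounds, a 5.0-fold higher number from compound 2 to compound 3 (0.70 log units; beyond the scatter), and it concerns the exchange of one five-membered aromatic ring for another at the saturated chain carbon bound to the amine nitrogen. It does not touch the substituent on the aromatic carbon and therefore says little about the change from compound 1 to compound 4. Compound 1 and compound 2 carry different groups on their thiophene rings, yet their values sit within the scatter of each other, which suggests that such groups have not moved the read-out much so far.

For the measured compounds named here, with no direct precedent, compound 4 is expected to remain close to compound 1, and the step of a 1.3-fold lower number from compound 1 to compound 4 (0.10 log units; within the scatter) is estimated to fall within the scatter. Compound 4 is estimated at 10000 nM, with a range from 4000 nM to 25000 nM.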

Compound 4, minimum cytotoxic concentration: 780 nM
The estimate for compound 4 lay 13-fold (1.11 log units) above the measured number; the whole stated range lies above it.
By their numbers in this assay, from the lowest: compound 4; then compounds 2 and 1 (each within the scatter of the next); then compound 3.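

In this assay, cyclohexyl in place of butyl on an aromatic carbon gives a 16-fold lower number from compound 1 to compound 4 (1.20 log units; beyond the scatter), a larger step than the only one recorded earlier, a 5.0-fold higher number from compound 2 to compound 3 (0.70 log units; beyond the scatter), which concerned the exchange of one aromatic ring for another. Among the compounds shown here, it is also the first reading at this position, two ring bonds from the ring sulfur, and it shows that the number responds strongly to what this carbon carries, even when one group of carbon only replaces another, with no hydrogen-bond donors or acceptors and no net charge on either side. Nothing among the data shown explains why this exchange moves the number so far.

The compounds shown leave open whether the step follows the closed ring of cyclohexyl or the larger count of carbons, a question that a hexyl chain, a cyclopentyl or a phenyl at this carbon could separate. They also leave open whether the low number would persist with an amine or a carboxylic acid on the cyclohexyl, or with cyclohexyl on the furan of compound 3.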